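Urea to amide on the shared core, before measurement

The compounds below may be only part of what the source reports. "The series", "measured", "known", "first", "only" and "open" are said of these compounds alone.

Compound 2 `COc1cc(Cl)cc(-c2nn(-c3cccc(NC(=O)Nc4ccc(Cl)c(Cl)c4)c3)cc2-c2ccncc2)c1` has been tested in a functional assay on OVCAR-4 cells (Homo sapiens) for inhibition, read by sulforhodamine B assay, with a stated time of 48 h, tested at 0.1 uM (on this read-out higher numbers stand for a weaker effect at the one concentration tested and lower numbers for a stronger effect), and compound 2 gives 95%. In this assay compound 1 `O=C(Nc1cccc(-n2cc(-c3ccncc3)c(-c3cc(O)cc(Cl)c3)n2)c1)Nc1ccc(Cl)c(Cl)c1` gives 95%, so the two stand level. Among the compounds with values here, the only measured step, no change at the digits printed from compound 1 to compound 2 (within the scatter), is a methyl in place of hydrogen on an oxygen on an aromatic ring, and it left the read-out unchanged within the scatter. Compound 3 `COc1cc(Cl)cc(-c2nn(-c3cccc(NC(=O)c4cccc(C(F)(F)F)c4)c3)cc2-c2ccncc2)c1` differs from compound 2 elsewhere: 3-(trifluoromethyl)phenyl in place of (3,4-dichlorophenyl)amino on a carbonyl carbon. Within the data shown here, no measured step touches that carbonyl carbon or its neighbours, so the measured pair offers no guide to the size of this change in either direction. With both measured compounds sitting near the weak end of the read-out, the step of a number 1 percentage points lower from compound 2 to compound 3 (within the scatter) is expected to remain within the scatter. Compound 3 is therefore estimated at 94%, with a range from 80% to 105%.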

Compound 3, a percentage reported as activity, at one concentration (the size of the read-out at that concentration, not a potency): 95%
For compound 3 the middle estimate is 1 percentage points below the measured one; the range from low to high includes it.
By their numbers in this assay, from the lowest: compounds 1, 2 and 3 (each within the scatter of the next).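

In this assay, replacing (3,4-dichlorophenyl)amino on the carbonyl carbon with 3-(trifluoromethyl)phenyl gives no change at the digits printed from compound 2 to compound 3 (within the scatter). Within the data shown here, this is the first measured change at this carbonyl carbon, and it shows that a urea can become an amide, with the hydrogen-bond donor of the leaving group gone, without shifting this read-out beyond the scatter. No supporting measurement bears on why the result stays level.

All three compounds sit near the weak end of this assay, so the compounds shown leave open whether any group on this carbonyl carbon can give a clearly stronger effect at the one concentration tested. A piperidine ring or a short chain ending in a carboxylic acid at this carbon would test that directly.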